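The source may report more compounds than this note shows. Statements on the series, on what has been measured and on what is new or still open speak of the compounds shown alone.

Measured so far in a functional assay on PC-3 cells (Homo sapiens) for antiproliferative activity, read by MTT assay, with a stated time of 72 h; a lower number here means a stronger inhibitor, a higher number a weaker inhibitor

- compound 1 `O=C(N/N=C/c1cccc(Br)c1)Nc1ccc(Oc2ccnc3[nH]ccc23)c(F)c1` gives 4020 nM here
- compound 2 `O=C(N/N=C/c1cccc([N+](=O)[O-])c1)Nc1ccc(Oc2ccnc3[nH]ccc23)c(F)c1` gives 5140 nM here
- compound 3 `O=C(N/N=C/c1ccc(Cl)c(Cl)c1)Nc1ccc(Oc2ccnc3[nH]ccc23)c(F)c1` gives 14100 nM here

Of these three, compound 3 has the highest number and is therefore the weakest inhibitor. The next change leads from compound 3 to compound 4 `O=C(N/N=C/c1cc(Br)c(O)c(Br)c1)Nc1ccc(Oc2ccnc3[nH]ccc23)c(F)c1` and leaves the shared core untouched. It places 3,5-dibromo-4-hydroxyphenyl in place of 3,4-dichlorophenyl on a carbon with a double bond to nitrogen and is the only difference between the two.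

All three measured steps change this same part of the molecule. Putting nitro in place of bromo gives a 1.3-fold higher number from compound 1 to compound 2 (0.11 log units; within the scatter) in this series. Moving to the 3,4-dichlorophenyl group gives a 3.5-fold higher number from compound 1 to compound 3 (0.54 log units; beyond the scatter) and also a 2.7-fold higher number from compound 2 to compound 3 (0.44 log units; beyond the scatter) as a second comparison. Among the compounds with values here, no measured compound carries the 3,5-dibromo-4-hydroxyphenyl group, so these steps offer only a rough guide to its size. Compound 3, at 14100 nM on this scale, lies at the top of the measured range, and a new group is more likely to land lower than higher. A small step toward a lower number is therefore expected in this assay and it may not exceed the scatter. The estimated change is a 1.8-fold lower number from compound 3 to compound 4 (0.25 log units; within the scatter) in this case. For compound 4 the estimated value is 8000 nM with an expected range from 2800 nM to 22000 nM in this assay.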

Compound 4, half-maximal inhibitory concentration: "not active" (no number reported)
Nothing numeric was reported for compound 4, so the estimate cannot be set against anything.
By their numbers in this assay, from the lowest: compounds 1 and 2 (each within the scatter of the next); then compound 3.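

In this assay, within the data shown here, compound 4 is reported only as "not active", with no number, so no step from compound 3 to compound 4 can be read. Nothing available here bears on the reason for this result.

The compounds shown leave open how far compound 4 lies from compound 3 on this scale, and what the 3,5-dibromo-4-hydroxyphenyl group contributes.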